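Aryl urea in place of alkyl urea on the shared core

The compounds below may be only part of what the source reports. "The series", "measured", "known", "first", "only" and "open" are said of these compounds alone.

Measured compounds:
compound 1 `CCS(=O)(=O)N1CCN(c2ccc(OCC3CCN(C(=O)OC(C)C)CC3)cn2)CC1` 1300 nM
compound 2 `CCN(CC)S(=O)(=O)N1CCN(c2ccc(OCC3CCN(C(=O)OC(C)C)CC3)cn2)CC1` 1200 nM
compound 3 `CCCS(=O)(=O)N1CCN(c2ccc(OCC3CCN(C(=O)NC(C)C)CC3)cn2)CC1` 1000 nM

In a functional assay on CHO-K1 cells for agonist activity at Glucose-dependent insulinotropic receptor (Homo sapiens), read by a luciferase reporter, with a stated time of 5 h (a higher number here means that more compound is needed for the effect, a lower number that less compound is needed), compound 3 sits alongside compound 1 and compound 2, with the gaps to both within the scatter. Compound 4 `CCCS(=O)(=O)N1CCN(c2ccc(OCC3CCN(C(=O)Nc4ccc(C(C)C)cc4)CC3)cn2)CC1` differs from compound 3 by 4-isopropylphenyl in place of isopropyl on an amide-type nitrogen. Among the compounds with values here, the single measured step, a 1.1-fold lower number from compound 1 to compound 2 (0.03 log units; within the scatter), changes a sulfonyl substituent and does not touch the amide-type nitrogen, so no measured step bears on this change. The three numbers of compound 1, compound 2 and compound 3 lie close together despite changes in two other places. For compound 4 the estimate is 700 nM, within 150 nM to 4000 nM. The expected step of a 1.4-fold lower number from compound 3 to compound 4 (0.15 log units; within the scatter) is therefore uncertain in direction and carries a wide range.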

Compound 4, half-maximal effective concentration: 900 nM
For compound 4 the middle estimate is 1.3-fold (0.11 log units) below the measured one; the range from low to high includes it.
By their numbers in this assay, from the lowest: compounds 4, 3, 2 and 1 (each within the scatter of the next).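

Putting 4-isopropylphenyl in place of isopropyl on the amide-type nitrogen gives a 1.1-fold lower number from compound 3 to compound 4 (0.05 log units; within the scatter) in this assay. This position therefore accepts a six-membered aromatic ring of carbon only, and the larger group leaves the number indistinguishable from that of the isopropyl compound. Nothing available accounts for this result.

Going by these compounds, it remains open whether plain phenyl, or a phenyl carrying a carboxylic acid or an amine, would give a similar number at this nitrogen. The same question stands for a longer alkyl chain there.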